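Bromo to Trifluoromethyl on a Second Amide Core

This account rests on a few compounds, and the source may have more. Where it says the series, first, only, none or still open, it means among the compounds named here.

Measured compounds in a functional assay on HepG2 cells (Homo sapiens) for cytotoxicity, with a stated time of 24 h; a higher number here means a weaker inhibitor, a lower number a stronger inhibitor:
compound 1, `COc1cc(Cl)ccc1C(=O)Nc1ccc(Br)cc1O`, gives 46600 nM
compound 2, `COc1cc(Cl)ccc1C(=O)Nc1ccc(C(F)(F)F)cc1O`, gives 3900 nM
compound 3, `COc1ccc(Cl)cc1C(=O)Nc1ccc(Br)cc1O`, gives 7980 nM

Three amides have been measured so far, and a fourth, compound 4, `COc1ccc(Cl)cc1C(=O)Nc1ccc(C(F)(F)F)cc1O`, is still to be tested. Compounds 1 and 2 share one core, and the change between them is trifluoromethyl in place of bromo on an aromatic carbon. That step in this assay is a 12-fold lower number from compound 1 to compound 2 (1.08 log units; beyond the scatter), a large move toward a stronger inhibitor.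

Compound 3 is built on a different core from compound 1: the two have the same atoms joined differently, and the difference between the two cores is not broken down here. In this assay compound 3 stands about midway between the other two, with a number beyond the scatter from both.

Compound 4 carries the same change on the core of compound 3: trifluoromethyl in place of bromo on an aromatic carbon. The place line is the same word for word as for the first pair, so the change is the same, appearing in two pairs among the compounds shown. For the measured compounds named here, whether the core of compound 3 responds to it as the core of compound 1 did is the open question; nothing measured yet tells how the two cores differ in their response, so the expectation rests on the single measured step.

The step from compound 3 to compound 4 is expected to be an 8.0-fold lower number from compound 3 to compound 4 (0.90 log units; beyond the scatter), somewhat smaller than the first because a 12-fold lower number from compound 1 to compound 2 (1.08 log units; beyond the scatter) is a single observation and a repeat on a new core often falls short of it. Compound 4 is therefore expected to give about 1000 nM in this assay. The range for compound 4 is estimated to run from 350 nM to 3500 nM.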

Compound 4, half-maximal inhibitory concentration: 4910 nM
For compound 4 the middle estimate is 4.9-fold (0.69 log units) below the measured one; the whole stated range lies below it.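

Trifluoromethyl in place of bromo on the core of compound 3 gives, in this assay, a 1.6-fold lower number from compound 3 to compound 4 (0.21 log units; within the scatter), so on this core the two groups cannot be told apart by this measurement. The large step seen on the core of compound 1 therefore did not carry over to the second core, and the two steps truly differ: the same change on two cores in this assay, a 12-fold lower number (1.08 log units; beyond the scatter) from compound 1 to compound 2 and a 1.6-fold lower number (0.21 log units; within the scatter) from compound 3 to compound 4, 7.4-fold (0.87 log units) apart, beyond the scatter of two such steps

This shows that, within these two pairs, the result of the swap depends on the core it is made on, so a step measured on one core is a poor guide to the same swap on the other. It does not show which feature of the cores, which hold the same atoms joined differently, sets the difference, nor does it give a rule for any further core, since it rests on just two pairs in one assay.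

The compounds shown leave open how a nitrile, a methyl group or a carboxylic acid at the same place would behave on each of the two cores, and whether the two cores would again part ways. They also leave open what an amine in place of the hydroxy group would do on either core.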